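Cytotoxicity of a chloroquinolinone ester series

This account rests on a few compounds, and the source may have more. Where it says the series, first, only, none or still open, it means among the compounds named here.

Measured so far in an ADME assay on HepG2 2.2.15 cells (Homo sapiens) for cytotoxicity; a higher number here means that more compound is tolerated, a lower number that less compound is tolerated:
compound 1 `C=CCn1c(=O)c(CCO)c(-c2ccccc2Cl)c2cc(Cl)ccc21` — 23000 nM
compound 2 `CC(=O)OCC(=O)OCCc1c(-c2ccccc2Cl)c2cc(Cl)ccc2[nH]c1=O` — 100000 nM
compound 3 `CC(=O)N1CCC(C(=O)OCCc2c(-c3ccccc3Cl)c3cc(Cl)ccc3[nH]c2=O)CC1` — 82000 nM

Compound 3 gives the second highest of the three numbers in this assay. Its nearest neighbour is compound 2, whose value lies within the scatter of it; the furthest is compound 1, whose number is lower by a margin beyond the scatter.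

The next compound, compound 4 `C/C=C/C(=O)OCCc1c(-c2ccccc2Cl)c2cc(Cl)ccc2[nH]c1=O`, differs from compound 3 at the ester: prop-1-en-1-yl in place of 1-acetylpiperidin-4-yl on a carbonyl carbon.

Among the measured compounds shown here, only one measured step bears on this position, the exchange of the ester substituent on the carbonyl carbon, a 1.2-fold lower number from compound 2 to compound 3 (0.09 log units; within the scatter). That exchange of one acyl group for another left the read-out unchanged within the scatter. The present change sits at the same carbonyl carbon, so no step beyond the scatter is expected in this assay; the estimated step is a 1.0-fold lower number from compound 3 to compound 4 (0.01 log units; within the scatter).

For compound 4 the expected value in this assay is 80000 nM, within a range of 35000 nM to 180000 nM.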

Compound 4, half-maximal cytotoxic concentration: 30000 nM
Estimate against measurement, compound 4: 2.7-fold (0.43 log units) above; the whole stated range lies above it.
By their numbers in this assay, from the lowest: compounds 1 and 4 (each within the scatter of the next); then compounds 3 and 2 (each within the scatter of the next).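

In this assay the group on this carbonyl carbon does matter: prop-1-en-1-yl in place of 1-acetylpiperidin-4-yl gives a 2.7-fold lower number from compound 3 to compound 4 (0.44 log units; beyond the scatter), and prop-1-en-1-yl in place of acetoxymethyl gives a 3.3-fold lower number from compound 2 to compound 4 (0.52 log units; beyond the scatter). The earlier exchange at the same carbon, 1-acetylpiperidin-4-yl in place of acetoxymethyl, stayed within the scatter (a 1.2-fold lower number from compound 2 to compound 3 (0.09 log units; within the scatter)), so that step alone did not describe the position. This carbonyl carbon therefore accepts some exchanges of the acyl group without a shift in the read-out, but not all of them.

Going by these compounds, whether the lower number belongs to prop-1-en-1-yl specifically or extends to other small acyl groups stays open, and a saturated propyl chain, a longer alkenyl chain or a piperidine with a free amine would help to separate these readings. No measured evidence on these compounds accounts for the drop.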